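A few compounds are considered here, and "the series" means these few. Any claim that something is new, unique, unknown or untested is made for them only; others in the source may bear on it.

In a functional assay on the whole organism with Mus musculus as the target (on this read-out higher numbers stand for an effect only at larger amounts of compound and lower numbers for an effect already at smaller amounts), compound 1 (`CCCN(c1ccncc1)n1cccc1`) gives > 20 mg/kg, which is a limit. Compound 2 (`CCCCN(c1ccncc1)n1cccc1`) gives > 20 mg/kg, also a limit. Compound 3 (`c1ccc(CN(c2ccncc2)n2cccc2)cc1`) stands at > 20 mg/kg, again a limit and not a number. Within the data shown here, the series so far rests on one mark: the limit of > 20 mg/kg in this assay, at which 3 of the 3 values shown sit. Compound 4 (`C#CCN(c1ccncc1)n1cccc1`) replaces the phenyl of compound 3 with ethynyl on a saturated chain carbon bound to a nitrogen on an aromatic ring: ethynyl in place of phenyl on a saturated chain carbon bound to a nitrogen on an aromatic ring. The measured steps that bear on this are a step that the two limits leave unreadable from compound 1 to compound 3, a step that the two limits leave unreadable from compound 2 to compound 3 and a step that the two limits leave unreadable from compound 1 to compound 2, and none has a readable size. They therefore support no particular size or direction, and the expected change is none beyond the scatter. The estimated step is a step that the limit leaves unreadable from compound 3 to compound 4. For compound 4 the expected value is 25 mg/kg, with an estimated range of 10 mg/kg to 60 mg/kg.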

Compound 4, dose for half-maximal effect: > 20 mg/kg
Compound 4: a limit, no number; the forecaster's own chance of this, stated with the estimate: 60%; the middle value lies beyond the limit too.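

Among these compounds, compound 4 gives > 20 mg/kg, a limit and not a number, so no step linking compound 1, compound 2, compound 3 and compound 4 can be read. The compounds shown leave open whether changing this chain group shifts the read-out at all: the limit of > 20 mg/kg in this assay, at which 4 of the 4 values shown sit.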